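Prostacyclin synthase series: ether aryl group replaced by benzyl

The source may hold more compounds than are shown below. What is called first, only, known or untested is meant among the compounds shown, and "the series" means these compounds.

Compound 1 `CSc1ccc(OC(C)(C)C2OCC(C/C=C\CCC(=O)O)C(c3cccnc3)O2)c([N+](=O)[O-])c1` gives 5000 nM in an assay for inhibition of prostacyclin synthase (Homo sapiens), using microsomes; a lower number here means a stronger inhibitor, a higher number a weaker inhibitor. Compound 2 `Cc1ccc(OC(C)(C)C2OCC(C/C=C\CCC(=O)O)C(c3cccnc3)O2)cc1` gives 25000 nM, a change of a 5.0-fold higher number from compound 1 to compound 2 (0.70 log units; beyond the scatter). Compound 3 `CSc1ccccc1OC(C)(C)C1OCC(C/C=C\CCC(=O)O)C(c2cccnc2)O1` reaches only the limit of the assay, > 100000 nM, so its value is a bound and not a number (the limit of > 100000 nM in this assay, at which 1 of the 3 values shown sits). Against the two measured compounds its steps are an at least 20-fold higher number from compound 1 to compound 3 (1.30 log units; beyond the scatter) and an at least 4.0-fold higher number from compound 2 to compound 3 (0.60 log units; beyond the scatter), so compound 3 stands at the weak end of what has been measured in this assay.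

Compound 4 `CC(C)(Cc1ccc(F)cc1)C1OCC(C/C=C\CCC(=O)O)C(c2cccnc2)O1` is not yet measured. It differs from compound 3 by 4-fluorobenzyl in place of 2-(methylsulfanyl)phenoxy on a saturated chain carbon bound to two saturated chain carbons and a saturated ring carbon. Among the measured compounds shown here, no measured step covers this change: the steps to compound 3 only show that the 2-(methylsulfanyl)phenyl group gave the weakest result, and compounds 1 and 2 show that other groups on the same oxygen return numbers well within the range of this assay. For the measured compounds named here, the change to compound 4 removes the oxygen link as well as the aryl substituent, which none of the measured pairs addresses.

Compound 4 is therefore expected to fall below the limit, with a step estimated at an at least 3.3-fold lower number from compound 3 to compound 4 (0.52 log units; beyond the scatter). The estimate for compound 4 is 30000 nM, within a range of 5000 nM to 150000 nM, with a real chance that only a limit is reported again.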

Compound 4, half-maximal inhibitory concentration: 2000 nM
For compound 4 the middle estimate is 15-fold (1.18 log units) above the measured one; measured number below the stated range.
By their numbers in this assay, from the lowest: compound 4; then compound 1; then compound 2. At a limit, above all of these: compound 3.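

In this assay the change from an aryloxy group to 4-fluorobenzyl on this saturated chain carbon lowers the number in both readable pairs, with an at least 50-fold lower number from compound 3 to compound 4 (1.69 log units; beyond the scatter) and a 13-fold lower number from compound 2 to compound 4 (1.10 log units; beyond the scatter) as the two steps. Compound 3 stands at a limit, so the first of these steps is a bound and not a number: the limit of > 100000 nM in this assay, at which 1 of the 4 values shown sits. The earlier steps shown here varied only the aryl group on the oxygen, whereas these two show that this place also tolerates loss of that oxygen, since the carbon-linked 4-fluorobenzyl of compound 4 gives a lower number than the 2-(methylsulfanyl)phenoxy and 4-methylphenoxy groups it replaces.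

Each step changes the link and the ring substituent together, so the shift cannot yet be assigned to the loss of the oxygen or to the fluorine; a 4-fluorophenoxy group and an unsubstituted benzyl group at this place would separate the two. Also open, going by these compounds, is how far the distance to the ring can go, for example with a longer chain such as 2-phenylethyl.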